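From compound 3 to compound 4: phenyl to 4-bromophenyl

This account rests on a few compounds, and the source may have more. Where it says the series, first, only, none or still open, it means among the compounds named here.

Measured so far in an ADME assay on Vero 76 cells (Chlorocebus sabaeus) for cytotoxicity, read by MTT assay, with a stated time of 96 h (a higher number here means that more compound is tolerated, a lower number that less compound is tolerated), and shown below
- compound 1 `FC(F)(F)c1ccc(NCc2cn(-c3ccccc3)nc2-c2ccc(Br)cc2)cc1` gives 28000 nM
- compound 2 `Cc1ccc(NCc2cn(-c3ccccc3)nc2-c2ccc(C)cc2)cc1` gives the limit > 100000 nM
- compound 3 `Cc1ccc(NCc2cn(-c3ccccc3)nc2-c2ccccc2)cc1` gives the limit > 100000 nM

Compound 3 has no number in this assay but only the limit > 100000 nM as its reading. Compound 4 `Cc1ccc(NCc2cn(-c3ccccc3)nc2-c2ccc(Br)cc2)cc1` differs from it by bromo in place of hydrogen on an aromatic carbon in the form of bromo in place of hydrogen on an aromatic carbon. Among the compounds with values here, the one measured step is a step that the two limits leave unreadable from compound 2 to compound 3 and it offers no size to carry over. Within the data shown here, compound 1 also bears the 4-bromophenyl, differs elsewhere, and gives 28000 nM as the only number available. A moderate move toward less tolerated compound is therefore expected, namely an at least 2.0-fold lower number from compound 3 to compound 4 (0.30 log units; that floor lies within the scatter) as the estimated step. The expected value for compound 4 is 50000 nM (estimated range 20000 nM to 100000 nM).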

Compound 4, half-maximal cytotoxic concentration: > 100000 nM
Compound 4 gave a limit, no number; the forecaster's own chance of this, stated with the estimate: 35%; at least 2.0-fold (0.30 log units) between middle value and limit.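

In this assay compound 4 gives > 100000 nM as a limit and not a number. Within the data shown here, with the trifluoromethyl held fixed out of the comparison, methyl in place of trifluoromethyl gives an at least 3.5-fold higher number from compound 1 to compound 4 (0.55 log units; beyond the scatter) and so ties the one measured number to the trifluoromethyl together with the bromo, not to the 4-bromophenyl alone. The steps among compound 2, compound 3 and compound 4 cannot be read, since all rest on limits: the limit of > 100000 nM in this assay, at which 3 of the 4 values shown sit.

Going by these compounds, whether trifluoromethyl without the bromo would give a number stays open. So does how a carboxylic acid or an amine in place of the bromo would read.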